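Phenyl in Place of Methyl on a Carbonyl Carbon

The source may hold more compounds than are shown below. What is called first, only, known or untested is meant among the compounds shown, and "the series" means these compounds.

Compound 1 `CCC(/C=C(\COC(C)=O)C(=O)c1ccc(OC)cc1)CC` and compound 2 `CCC(/C=C(\COC(=O)c1ccccc1)C(=O)c1ccc(OC)cc1)CC` share one core, while compound 3 `C=C(C(=O)c1ccc(OC)cc1)C(OC(C)=O)c1ccccc1F` and compound 4 `C=C(C(=O)c1ccc(OC)cc1)C(OC(=O)c1ccccc1)c1ccccc1F` share another; the difference between the two cores is not broken down here. In a functional assay on A549 cells (Homo sapiens) for inhibition, read by XTT assay, with a stated time of 48 h (a lower number here means a stronger inhibitor, a higher number a weaker inhibitor), compound 1 gives > 100000 nM, which is a limit of the assay and not a number. Compound 2 likewise gives > 100000 nM in this assay, again a limit. The change between them, (phenyl in place of methyl on a carbonyl carbon), therefore leaves a step that the two limits leave unreadable from compound 1 to compound 2; this rests on (the limit of > 100000 nM in this assay, at which 2 of the 3 values shown sit). Compound 3, by contrast, gives a number in this assay: 67300 nM. Compound 4 carries the same change, (phenyl in place of methyl on a carbonyl carbon), on the second core. The measured pair gives no readable size for this change. The expectation rests mainly on compound 3 with its 67300 nM. For compound 4 the step of a 1.1-fold lower number from compound 3 to compound 4 (0.05 log units; within the scatter) is expected to stay small. Compound 4 is thus estimated at 60000 nM in this assay, within 15000 nM to 150000 nM.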

Compound 4, half-maximal inhibitory concentration: 73700 nM
Compound 4: the middle estimate sits 1.2-fold (0.09 log units) below what was measured; low and high end bracket the measured number.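

In this assay the change from acetoxy to benzoyloxy on the core of compound 3 gives a 1.1-fold higher number from compound 3 to compound 4 (0.04 log units; within the scatter), so on this core the two compounds cannot be told apart, and phenyl in place of methyl on a carbonyl carbon is tolerated without any readable cost. This does not show that the change behaves the same way on the core of compound 1, where the step to compound 2 cannot be read: the limit of > 100000 nM in this assay, at which 2 of the 4 values shown sit. The series therefore offers one readable step on one core, and the pair on the other core neither supports nor contradicts it.

The compounds shown leave open whether an amine or a longer chain in place of the phenyl on this carbonyl carbon would give a number apart from that of compound 3 in this assay. They also leave open whether the same change would stay within the scatter on any core other than that of compound 3.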